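Azido, amino and a limit in PC-3 cells

This account rests on a few compounds, and the source may have more. Where it says the series, first, only, none or still open, it means among the compounds named here.

Compound 1 `COc1ccc(CN(C(=O)CSc2nc3ccccc3s2)c2cc(OC)c(OC)c(OC)c2)cc1N=[N+]=[N-]`: 14400 nM
Compound 2 `COc1ccc(CN(C(=O)CSc2nc3ccccc3s2)c2cc(OC)c(OC)c(OC)c2)cc1OC`: > 80000 nM
Compound 3 `COc1cc(N(Cc2ccc(Cl)cc2)C(=O)CSc2nc3ccccc3s2)cc(OC)c1OC`: > 80000 nM

In a functional assay on PC-3 cells (Homo sapiens) for antiproliferative activity, read by MTT assay, with a stated time of 48 h (on this read-out higher numbers stand for weaker inhibition and lower numbers for stronger inhibition), compound 3 gives > 80000 nM, which is a limit and not a number. Compound 2 shares it, as the limit of > 80000 nM in this assay, at which 2 of the 3 values shown sit, records.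

Compound 4 `COc1ccc(CN(C(=O)CSc2nc3ccccc3s2)c2cc(OC)c(OC)c(OC)c2)cc1N` carries 3-amino-4-methoxyphenyl in place of 4-chlorophenyl on a saturated chain carbon bound to an amide-type nitrogen.

For the measured compounds named here, two measured steps bear on this, an at least 5.5-fold higher number from compound 1 to compound 3 (0.74 log units; beyond the scatter) and an at least 5.5-fold higher number from compound 1 to compound 2 (0.74 log units; beyond the scatter), both beyond the scatter. The step that the two limits leave unreadable from compound 2 to compound 3 adds nothing. The group in compound 4 resembles the 3-azido-4-methoxyphenyl of compound 1, which gives 14400 nM, so a lower number is expected. The expected change is an at least 3.2-fold lower number from compound 3 to compound 4 (0.50 log units; beyond the scatter). For compound 4 the estimated value is 25000 nM, with an expected range of 7000 nM to 80000 nM.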

Compound 4, half-maximal inhibitory concentration: 7510 nM
Compound 4: the middle estimate sits 3.3-fold (0.52 log units) above what was measured; the range from low to high includes it.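

On the saturated chain carbon bound to an amide-type nitrogen, 3-amino-4-methoxyphenyl in place of 4-chlorophenyl gives an at least 10-fold lower number from compound 3 to compound 4 (1.02 log units; beyond the scatter) in this assay. Amino in place of methoxy gives an at least 10-fold lower number from compound 2 to compound 4 (1.02 log units; beyond the scatter), so azido is no longer the only group shown that gives a measurable value here. Amino in place of azido gives a 1.9-fold lower number from compound 1 to compound 4 (0.28 log units; within the scatter), which lies within the scatter, so the two groups cannot be told apart in this assay.

The compounds shown leave open whether a hydroxyl or an acetamide group in place of the amino group would keep this activity.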